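The source may report more compounds than this note shows. Statements on the series, on what has been measured and on what is new or still open speak of the compounds shown alone.

Measured in a functional assay on A549 cells (Homo sapiens) for cytotoxicity, read by MTT assay; a lower number here means a stronger inhibitor, a higher number a weaker inhibitor:
- Compound 1 `COc1ccc(-c2oc3c(CC=C(C)C)c(OC(C(=O)O)C(=O)O)cc(O)c3c(=O)c2OC(C(=O)O)C(=O)O)cc1`: > 100000 nM (a limit of the assay)
- Compound 2 `CCOC(=O)C(C)Oc1cc(O)c2c(=O)c(O)c(-c3ccc(OC)cc3)oc2c1CC=C(C)C`: 26500 nM

Within the data shown here, compound 2, at 26500 nM, gives the only exact number so far. Compound 1 reads > 100000 nM, which is a limit of the assay and not a number.

Compound 3 `COc1ccc(-c2oc3c(CC=C(C)C)c(OC(C)C(=O)O)cc(O)c3c(=O)c2O)cc1` is compound 2 with a single change: hydrogen in place of ethyl on an oxygen next to a carbonyl group. This puts hydrogen in place of ethyl on an oxygen next to a carbonyl group, so the ethoxycarbonyl group becomes a carboxy group.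

Among the measured compounds shown here, no measured pair of compounds shows this change alone, so any forecast rests on thin evidence. For the measured compounds named here, the one hint comes from compound 1, which also carries carboxy groups and reads > 100000 nM, although it differs from compound 2 in other ways too. A modest move towards weaker inhibition in this assay is therefore expected, and a result reported only as a limit would be no surprise. The expected change is a 2.1-fold higher number from compound 2 to compound 3 (0.32 log units; beyond the scatter). For compound 3 the estimated value is 55000 nM, with an expected range of 20000 nM to 100000 nM.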

Compound 3, half-maximal inhibitory concentration: 15300 nM
Beside the measured number, compound 3's estimate is 3.6-fold (0.56 log units) above it; the whole stated range lies above it.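

Replacing ethyl with hydrogen on an oxygen next to a carbonyl group, which turns ethoxycarbonyl into carboxy, gives a 1.7-fold lower number from compound 2 to compound 3 (0.24 log units; within the scatter). Among these compounds, this pair is the first direct reading of this change, since the earlier compounds offered no two structures differing in one place, and it shows that the ethyl ester and the free acid cannot be told apart in this assay. Compound 3 also carries a carboxy group and still gives an exact number, so having a carboxy group at this place does not by itself produce the kind of reading seen for compound 1, which is a limit of the assay and not a number: the limit of > 100000 nM in this assay, at which 1 of the 3 values shown sits.

The compounds shown leave open whether a methyl ester, an amide or a longer chain on that oxygen would give a number clearly different from these two. They also leave open whether the 1-carboxyethyl group could be replaced by something quite different, such as an amine, and whether the same swap would read alike on another core, as this single pair speaks only for the shared core of compound 2 and compound 3.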